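The source may report more compounds than this note shows. Statements on the series, on what has been measured and on what is new or still open speak of the compounds shown alone.

Compound 1 `CCCCCCC(CCO)n1cnc2c(OC)ncnc21` and compound 3 `CCCCCCCC(CCO)n1cnc2c(OC)ncnc21` share a core and differ by methyl in place of hydrogen on a saturated chain carbon, seven bonds along the chain from an aromatic nitrogen. In a functional assay on SW480 cells (Homo sapiens) for antiproliferative activity, read by MTT assay, with a stated time of 48 h (a lower number here means a stronger inhibitor, a higher number a weaker inhibitor), compound 1 gives only a limit, > 50000 nM. Compound 3 gives 23900 nM, so the step of an at least 2.0-fold lower number from compound 1 to compound 3 (0.32 log units; beyond the scatter). Compound 2 `CCCCCCC(CCO)n1cnc2c(NC)ncnc21` differs from compound 1 by methylamino in place of methoxy on an aromatic carbon. Compound 2 likewise reaches only a limit, > 50000 nM. Hence the step that the two limits leave unreadable from compound 1 to compound 2, a result tied to the limit of > 50000 nM in this assay, at which 2 of the 3 values shown sit. Compound 4 `CCCCCCCC(CCO)n1cnc2c(NC)ncnc21` carries the same change from compound 3, (methylamino in place of methoxy on an aromatic carbon), at a place described in the same words. Because that change left no readable step in a step that the two limits leave unreadable from compound 1 to compound 2, the number for compound 4 is expected to sit close to that of compound 3, with a step of a 1.0-fold higher number from compound 3 to compound 4 (0.02 log units; within the scatter). Compound 4 is therefore estimated at 25000 nM, within 8000 nM to 80000 nM.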

Compound 4, half-maximal inhibitory concentration: 15300 nM
Beside the measured number, compound 4's estimate is 1.6-fold (0.21 log units) above it; the range from low to high includes it.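

In this assay, methylamino in place of methoxy gives a 1.6-fold lower number from compound 3 to compound 4 (0.19 log units; within the scatter), so this swap shows no clear effect here. From the compounds shown here alone, the chain change, methyl in place of hydrogen on a saturated chain carbon, gives an at least 3.2-fold lower number from compound 2 to compound 4 (0.51 log units; beyond the scatter), and it lowers the number on both cores, though its exact size on each remains unknown: the same change on two cores in this assay, an at least 2.0-fold lower number (0.32 log units; beyond the scatter) from compound 1 to compound 3 and an at least 3.2-fold lower number (0.51 log units; beyond the scatter) from compound 2 to compound 4; the limit leaves it open whether they differ. The methylamino swap cannot be read on the other core, so nothing shows whether it behaves the same on both cores, and the values there are limits, not numbers: the limit of > 50000 nM in this assay, at which 2 of the 4 values shown sit.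

The compounds shown leave open whether a longer chain would lower the number further. They also leave open whether an amino group or an ethoxy group on the aromatic carbon would read differently from methoxy and methylamino.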